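This account rests on a few compounds, and the source may have more. Where it says the series, first, only, none or still open, it means among the compounds named here.

Measured so far in an assay on tissue (HeLa cells) for inhibition of Indoleamine 2,3-dioxygenase 1 (Homo sapiens), with a stated time of 48 h; on this read-out lower numbers stand for stronger inhibition and higher numbers for weaker inhibition:
compound 1 `O=C(/C(=N/O)Nc1ccc(F)c(Br)c1)C1CCCCC1` gives 63 nM
compound 2 `O=C(NC[C@H]1CC[C@H](C(=O)/C(=N/O)Nc2ccc(F)c(Br)c2)CC1)c1ccccc1` gives 204 nM

Among the compounds with values here, compound 2 holds the higher of the two numbers in this assay; its only neighbour is compound 1, and the step of a 3.2-fold higher number from compound 1 to compound 2 (0.51 log units; beyond the scatter) is the sole measured step. Compound 3 `NS(=O)(=O)NC[C@H]1CC[C@H](C(=O)/C(=N/O)Nc2ccc(F)c(Br)c2)CC1` is not yet measured in this assay. It differs from compound 2 by sulfamoyl in place of benzoyl on an amine nitrogen. Within the data shown here, no measured step touches the group on that amine nitrogen: the one known step, from compound 1 to compound 2, installed the whole benzamidomethyl arm and cost a modest amount, so it shows only that this arm is carried with some loss and says nothing about what sits on the nitrogen. Among the measured compounds shown here, with no direct precedent, the expectation for compound 3 is a step near the scatter, a 1.4-fold higher number from compound 2 to compound 3 (0.14 log units; within the scatter), leaning slightly toward a higher number. Compound 3 is therefore estimated at 280 nM, within 90 nM to 900 nM.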

Compound 3, half-maximal inhibitory concentration: 21 nM
Beside the measured number, compound 3's estimate is 13-fold (1.12 log units) above it; measured number below the stated range.
By their numbers in this assay, from the lowest: compound 3; then compound 1; then compound 2.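

The group on the amine nitrogen carries much of the outcome in this assay: sulfamoyl in place of benzoyl gives a 9.7-fold lower number from compound 2 to compound 3 (0.99 log units; beyond the scatter). The arm on the saturated ring carbon therefore need not cost anything, since (sulfamoylamino)methyl in place of hydrogen gives a 3.0-fold lower number from compound 1 to compound 3 (0.48 log units; beyond the scatter), against the opposite direction for benzamidomethyl (a 3.2-fold higher number from compound 1 to compound 2 (0.51 log units; beyond the scatter)), so the direction of the arm's step depends on what sits on that nitrogen. No measurement available here accounts for this difference.

Still open, on these data alone, is whether an acetyl group, a methanesulfonyl group or the free amine on that nitrogen would fall with benzoyl or with sulfamoyl. Also open, as far as these compounds go, is whether the sulfamoyl gain would hold with a longer chain between the amine nitrogen and the saturated ring.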